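The compounds below may be only part of what the source reports. "The series", "measured", "known", "first", "only" and "open" are said of these compounds alone.

Compound 1 `COc1ccc(C2=NN(C3=NC(=O)/C(=C4\C(=O)Nc5ccccc54)S3)C(c3ccc(Cl)cc3)C2)cc1` and compound 2 `COc1ccc(C2=NN(C3=NC(=O)/C(=C4\C(=O)Nc5ccc(Br)cc54)S3)C(c3ccc(Cl)cc3)C2)cc1` differ in one place only: bromo in place of hydrogen on an aromatic carbon. In a functional assay on cells (Leukemia cell, Homo sapiens) for cytotoxicity, read by sulforhodamine B assay, with a stated time of 48 h (on this read-out lower numbers stand for stronger inhibition of growth and higher numbers for weaker inhibition of growth), compound 1 gives 86600 nM, while compound 2 gives 190 nM. That single change produced a 460-fold lower number from compound 1 to compound 2 (2.66 log units; beyond the scatter). Compound 3 `CN(C)c1ccc(C2CC(c3ccccc3)=NN2C2=NC(=O)/C(=C3\C(=O)Nc4ccccc43)S2)cc1` is built on a different core; how its core differs from the core of compound 1 is not broken down here. In this assay compound 3 gives 33900 nM, a number that lies above that of compound 1 and far above that of compound 2. Compound 4 `CN(C)c1ccc(C2CC(c3ccccc3)=NN2C2=NC(=O)/C(=C3\C(=O)Nc4ccc(Br)cc43)S2)cc1` has not yet been measured; it stands to compound 3 as compound 2 stands to compound 1, since bromo in place of hydrogen on an aromatic carbon is the same change at the same place of the fused ring system. If the change carries over to the new core, the step is expected to be a 230-fold lower number from compound 3 to compound 4 (2.35 log units; beyond the scatter), resting on a 460-fold lower number from compound 1 to compound 2 (2.66 log units; beyond the scatter). A single precedent of that size leaves room for the new core to respond differently, so the estimate for compound 4 is set at 150 nM, with a range from 30 nM to 1500 nM in this assay.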

Compound 4, concentration for 50% growth inhibition: 310 nM
Compound 4: middle estimate off by 2.1-fold (0.32 log units), on the low side, within the range that was stated.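

The same change works on the second core too: in this assay bromo in place of hydrogen gives a 110-fold lower number from compound 3 to compound 4 (2.04 log units; beyond the scatter) and so moves the number in the same direction as on the first core. The direction carried over, but the size did not carry over exactly, as the two steps show when set side by side: the same change on two cores in this assay, a 460-fold lower number (2.66 log units; beyond the scatter) from compound 1 to compound 2 and a 110-fold lower number (2.04 log units; beyond the scatter) from compound 3 to compound 4, 4.2-fold (0.62 log units) apart, beyond the scatter of two such steps. So in this series the step is large on both cores and its size depends in part on the core, but two pairs do not show what in the cores sets that size, nor whether the change would hold on a further core.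

The compounds shown have only hydrogen or bromo at this place on the fused ring system, so it remains open how fluoro, a methyl group or an amine would behave there. Also open, as far as these compounds go, is whether bromo would give a step of this kind on any other aromatic carbon of that ring.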